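Selenocyanate in place of bromo on the amide carbonyl

This account rests on a few compounds, and the source may have more. Where it says the series, first, only, none or still open, it means among the compounds named here.

Measured so far:
- compound 1 `COc1ccc(CN(C(=O)C(C)Br)c2cc(OC)c(OC)c(OC)c2)cc1O`: 160 nM
- compound 2 `COc1ccc(CNc2cc(OC)c(OC)c(OC)c2)cc1C`: 73800 nM

In a functional assay on KYSE-450 cells (Homo sapiens) for inhibition, read by MTT assay, with a stated time of 48 h (on this read-out higher numbers stand for weaker inhibition and lower numbers for stronger inhibition), compound 1 gives 160 nM and stands lowest of the two numbers; compound 2, the only other one, gives 73800 nM, a gap that lies beyond the scatter. Within the data shown here, no step between measured compounds differing in one place is available, so the move from compound 1 to compound 3 `COc1ccc(CN(C(=O)C[Se]C#N)c2cc(OC)c(OC)c(OC)c2)cc1O` is judged from the structural change alone.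

Compound 3 differs from compound 1 as follows: a group of 4 heavy atoms (2 carbon, 1 nitrogen, 1 selenium; no ring) in place of a group of 3 heavy atoms (2 carbon, 1 bromine; no ring), on a carbonyl carbon. The shared core, the amide-type nitrogen and the carbonyl carbon stay as they are in compound 1.

A change confined to the group on the carbonyl carbon, with the rest of compound 1 kept, is expected to leave the number in this assay near where compound 1 stands; the estimated step of a 1.3-fold higher number from compound 1 to compound 3 (0.10 log units; within the scatter) is therefore expected to fall within the scatter, in no clear direction. For compound 3 the estimate in this assay is 200 nM, with a range from 40 nM to 1000 nM.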

Compound 3, half-maximal inhibitory concentration: 280 nM
Beside the measured number, compound 3's estimate is 1.4-fold (0.15 log units) below it; measured number inside the range.
By their numbers in this assay, from the lowest: compounds 1 and 3 (each within the scatter of the next); then compound 2.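

In this assay, putting the selenium- and nitrile-bearing group in place of the 1-bromoethyl group on a carbonyl carbon gives a 1.8-fold higher number from compound 1 to compound 3 (0.24 log units; within the scatter), so the two numbers cannot be told apart. Among these compounds, this is the first step confined to a single place, and it shows that this position accepts two quite different groups, one carrying bromine and the other carrying selenium and a triple bond, with no difference in the number beyond ordinary assay variation. Nothing available bears on why the two groups give such similar numbers.

Going by these compounds, it remains open whether the number depends on the bromine or the selenium at all; a plain ethyl group, a thiocyanate with sulfur in place of selenium, or a longer chain on the same carbonyl carbon would address that. Compound 1 differs from compound 2 in more than one place, so the much higher number that compound 2 gives at 73800 nM cannot be assigned to the absence of the group on the amide-type nitrogen alone.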